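Solubility notes: ester to primary amide on the shared core

This account rests on a few compounds, and the source may have more. Where it says the series, first, only, none or still open, it means among the compounds named here.

Measured so far:
Compound 1 `COCCOC(=O)c1cc(N)c(Nc2ccc(C#N)cc2)cc1Oc1c(C)cc(/C=C/C#N)cc1C` gives 1.64 ug/mL
Compound 2 `Cc1cc(/C=C/C#N)cc(C)c1Oc1cc(Nc2ccc(C#N)cc2)c(N)cc1C(=O)NCCCO` gives 19.9 ug/mL

In a physicochemical assay for solubility, read by HPLC, with a stated time of 4 h, at pH 2 (on this read-out higher numbers stand for higher solubility and lower numbers for lower solubility), compound 1 stands lowest of the two numbers, with compound 2 above it. Going by the values given here, the single measured step, a 12-fold higher number from compound 1 to compound 2 (1.08 log units; beyond the scatter), is large. Compound 3 `Cc1cc(/C=C/C#N)cc(C)c1Oc1cc(Nc2ccc(C#N)cc2)c(N)cc1C(N)=O` differs from compound 1 by amino in place of 2-methoxyethoxy on a carbonyl carbon. As in compound 2, the 2-methoxyethoxy group on the carbonyl carbon is replaced by a nitrogen-linked group, here without the hydroxypropyl chain, so only part of that step is taken as the guide. Compound 3 is expected at 8 ug/mL, range 2.5 ug/mL to 30 ug/mL. The expected step is a 4.9-fold higher number from compound 1 to compound 3 (0.69 log units; beyond the scatter), upward and beyond the scatter.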

Compound 3, solubility: 2.09 ug/mL
For compound 3 the middle estimate is 3.8-fold (0.58 log units) above the measured one, outside the stated range (below it).
By their numbers in this assay, from the lowest: compounds 1 and 3 (each within the scatter of the next); then compound 2.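

In this assay, amino in place of 2-methoxyethoxy on the carbonyl carbon gives a 1.3-fold higher number from compound 1 to compound 3 (0.11 log units; within the scatter), so that change alone does not reproduce the step to compound 2. Hydrogen in place of 3-hydroxypropyl on the amide-type nitrogen gives a 9.5-fold lower number from compound 2 to compound 3 (0.98 log units; beyond the scatter), placing the large difference among these three compounds with the 3-hydroxypropyl group rather than with the carbamoyl group. No supporting measurement explains this.

From the compounds shown here alone, whether the difference follows the hydroxyl or the chain remains open. A plain propyl chain or a chain ending in an amine on that nitrogen would separate the two.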